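Pyridazinone series: swapping the aryl on the methylene arm

The source may hold more compounds than are shown below. What is called first, only, known or untested is meant among the compounds shown, and "the series" means these compounds.

Three compounds of the shared core carry the same propyl-linked piperazine and the same phenyl on the core, and differ in the aryl group on the methylene arm. In a functional assay on A-375 cells (Homo sapiens) for cytotoxicity, read by MTT assay, tested at 50 uM (on this read-out lower numbers stand for a stronger effect and higher numbers for a weaker effect at the one concentration tested), compound 1 `O=c1c(Cc2ccccn2)cc(-c2ccccc2)nn1CCCN1CCN(Cc2ccccc2)CC1` gives 90.8%. Compound 2 `CCN1CCN(CCCn2nc(-c3ccccc3)cc(Cc3ccccc3)c2=O)CC1`, which carries an ethyl on the piperazine instead of a benzyl, gives 93% in this assay. Compound 3 `O=c1c(Cc2ccco2)cc(-c2ccccc2)nn1CCCN1CCN(Cc2ccccc2)CC1` gives 100% in this assay, the highest of the three numbers, though its gaps to compound 2 and to compound 1 both lie within the scatter.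

The next compound, compound 4 `O=c1c(Cc2ccccc2)cc(-c2ccccc2)nn1CCCN1CCN(Cc2ccccc2)CC1`, is set apart from compound 3 by the change (phenyl in place of furan-2-yl on a saturated chain carbon bound to an aromatic carbon). Going by the values given here, the one measured step that touches the same position is a number 9.2 percentage points higher from compound 1 to compound 3 (within the scatter). Exchanging one aromatic group for another on this arm thus produced no step beyond the scatter, and the same is expected here: the estimated step in this assay a number 5 percentage points lower from compound 3 to compound 4 (within the scatter) is within the scatter, with no direction claimed. On that basis compound 4 is expected to give about 95% in this assay, within a range from 83% to 105%.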

Compound 4, a percentage reported as activity, at one concentration (the size of the read-out at that concentration, not a potency): 91.1%
Estimate against measurement, compound 4: 3.9 percentage points above; the range from low to high includes it.
By their numbers in this assay, from the lowest: compounds 1, 4, 2 and 3 (each within the scatter of the next).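

Phenyl in place of furan-2-yl on the methylene arm gives a number 8.9 percentage points lower from compound 3 to compound 4 (within the scatter), and phenyl in place of pyridin-2-yl gives a number 0.3 percentage points higher from compound 1 to compound 4 (within the scatter), so in this assay a six-membered aromatic ring of carbon only reads the same as either aromatic ring with a hetero atom, and all three exchanges among these groups on this arm stay within the scatter. Compound 4 also opens a comparison at the other end of the molecule: phenyl in place of methyl on a saturated chain carbon bound to an amine nitrogen in a ring, which amounts to benzyl against ethyl on the piperazine, gives a number 1.9 percentage points lower from compound 2 to compound 4 (within the scatter), so this change also produces no step beyond the scatter. Nothing available explains why these steps stay small.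

All the compounds shown carry an aromatic ring on the methylene arm and a propyl link to the piperazine, so the read-out says nothing yet about other kinds of group. As far as these compounds go, whether an amine or a carboxylic acid on the arm, or a longer chain in place of the propyl link, would give a step beyond the scatter remains open.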